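From ethyl to phenyl on the nitrogen: working notes

The source may report more compounds than this note shows. Statements on the series, on what has been measured and on what is new or still open speak of the compounds shown alone.

Measured in a functional assay on KB cells (Homo sapiens) for cytotoxicity; a higher number here means that more compound is needed for the effect, a lower number that less compound is needed:
compound 1 `Nc1nc(N)c2nc(CNc3ccc(S(=O)(=O)N[C@@H](CCC(=O)O)C(=O)O)cc3)cnc2n1`: 45 ug/mL
compound 2 `CN(CCCCC(=O)N[C@@H](CCC(=O)O)C(=O)O)Cc1cnc2nc(N)nc(N)c2n1`: > 100 ug/mL, a limit of the assay
compound 3 `CCN(Cc1cnc2nc(N)nc(N)c2n1)c1ccc(C(=O)N[C@@H](CCC(=O)O)C(=O)O)cc1`: 0.005 ug/mL

Compound 3 holds the lowest of the two numeric values, and the gap to compound 1 lies well beyond the scatter. Compound 4 `Nc1nc(N)c2nc(CN(c3ccccc3)c3ccc(C(=O)N[C@@H](CCC(=O)O)C(=O)O)cc3)cnc2n1` has phenyl in place of ethyl on a nitrogen on an aromatic ring. Among the compounds with values here, no measured pair isolates this change. Within the data shown here, the values so far show that the number in this assay can differ widely, so a sizeable rise beyond the scatter is expected, with a 100-fold higher number from compound 3 to compound 4 (2.00 log units; beyond the scatter) as the estimated step. In this assay compound 4 is estimated at 0.5 ug/mL, with an expected range of 0.02 ug/mL to 20 ug/mL.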

Compound 4, concentration for half-maximal effect: 26 ug/mL
Compound 4: the middle estimate sits 52-fold (1.72 log units) below what was measured; measured number above the stated range.
By their numbers in this assay, from the lowest: compound 3; then compounds 4 and 1 (each within the scatter of the next). At a limit, above all of these: compound 2.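

On a nitrogen on an aromatic ring, the group carried counts heavily in this assay: phenyl in place of ethyl gives a 5200-fold higher number from compound 3 to compound 4 (3.72 log units; beyond the scatter). Within the data shown here, this is the first change read at a single place, and it shows that the low number of compound 3 does not survive this swap. No measurement shown gives a cause for this step.

Open, on these data alone, is how the number moves with groups between these two, such as propyl on the same nitrogen. Cyclohexyl there would show whether the rise goes with the aromatic ring or with the carbon count.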